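This account rests on a few compounds, and the source may have more. Where it says the series, first, only, none or still open, it means among the compounds named here.

Working notes on a small set of nucleoside-like compounds on a shared core, all tested in a functional assay (Homo sapiens) for inhibition of Nucleic Acid, tested at 100 uM; a lower number here means less inhibition, a higher number more inhibition at the concentration tested (going by the name of the read-out).

Compound 1 `OC[C@H]1OC(n2cnc3c(SCc4ccccc4)nccc32)[C@H](O)[C@@H]1O` gives 30% in this assay, the highest of the three numbers in hand. Compound 2 `OC[C@H]1O[C@@H](n2cnc3c(NCc4ccccc4)nccc32)C[C@@H]1O` gives 15%, a step down from compound 1 that lies beyond the scatter. Compound 3 `[O-][n+]1ccc2c(c1)ncn2C1O[C@H](CO)[C@@H](O)[C@H]1O` gives 5%, the furthest from compound 1, again beyond the scatter.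

Compound 4 `CNc1nccc2c1ncn2C1O[C@H](CO)[C@@H](O)[C@H]1O` is still to be measured. Against compound 1 the change is methylamino in place of benzylsulfanyl on an aromatic carbon. The expected step in this assay is a fall beyond the scatter, a number 18 percentage points lower from compound 1 to compound 4 (beyond the scatter), given that compound 2, with a benzylamino group, gives only 15%. For compound 4 the estimated inhibition is 12%, with a range from 0% to 28%.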

Compound 4, a percentage reported as inhibition, at one concentration (the size of the read-out at that concentration, not a potency): 8%
For compound 4 the middle estimate is 4 percentage points above the measured one; the measured number falls inside the stated range.
By their numbers in this assay, from the lowest: compounds 3, 4 and 2 (each within the scatter of the next); then compound 1.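

Methylamino in place of benzylsulfanyl on an aromatic carbon gives a number 22 percentage points lower from compound 1 to compound 4 (beyond the scatter) in this assay and is the only step in the series between compounds differing in one place. It shows that inhibition on the shared core changes with the group at this position. The change swaps the sulfur and the aromatic ring together, and no data in hand explain the step.

As far as these compounds go, whether the fall follows the sulfur or the benzyl part stays open, and methylsulfanyl on the core of compound 1 would separate the two. How a longer chain, such as phenethylsulfanyl, would read here is also unknown.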